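A few compounds are considered here, and "the series" means these few. Any claim that something is new, unique, unknown or untested is made for them only; others in the source may bear on it.

Measured so far:
- compound 1, `CC(C)(C)c1ccccc1Oc1ccc(-c2cccc(C(=O)O)c2)cc1NC(=O)Nc1ccc(Br)cc1`: 2900 nM
- compound 2, `Cc1ccc(NC(=O)Nc2cc(-c3ccc(Cl)c(C(=O)O)c3)ccc2Oc2ccccc2C(C)(C)C)cc1`: 2400 nM
- compound 3, `COc1ccc(-c2ccc(Oc3ccccc3C)c(NC(=O)Nc3ccc(C)cc3)c2)cc1C(=O)O`: 840 nM

All three numbers come from an assay on HeLa cells for inhibition of Indoleamine 2,3-dioxygenase 1 (Homo sapiens), with a stated time of 20 h; on this read-out higher numbers stand for weaker inhibition and lower numbers for stronger inhibition. Compound 3 holds the lowest number of the three; the gaps to compound 2 and to compound 1 both lie beyond the usual scatter, so compound 3 reads as the strongest inhibitor of this set. Compounds 1 and 2 differ from compound 3 in more than one place, so no single change can be tied to those gaps; their values stand only side by side.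

The next compound, compound 4, `COc1ccc(-c2ccc(Oc3cccc4c3CCC4)c(NC(=O)Nc3ccc(C)cc3)c2)cc1C(=O)O`, is not yet measured in this assay. It follows from compound 3 by one change: 2,3-dihydro-1H-inden-4-yl in place of 2-methylphenyl on an oxygen on an aromatic ring. The aryl ether on the shared core is kept; only the group on that oxygen is swapped.

Among the compounds with values here, no step between measured compounds isolates this kind of change, so the expectation rests on compound 3 alone. The larger group entering in place of the methyl-bearing ring is expected to leave the number near that of compound 3 or move it somewhat higher; the step of a 1.4-fold higher number from compound 3 to compound 4 (0.15 log units; within the scatter) is expected to be modest, possibly within the scatter. For compound 4 the estimate in this assay is 1200 nM, with a range from 400 nM to 3600 nM.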

Compound 4, half-maximal inhibitory concentration: 280 nM
The estimate for compound 4 lay 4.3-fold (0.63 log units) above the measured number; the measured number lies below the stated range.
By their numbers in this assay, from the lowest: compound 4; then compound 3; then compounds 2 and 1 (each within the scatter of the next).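

In this assay, within the data shown here, 2,3-dihydro-1H-inden-4-yl in place of 2-methylphenyl on an oxygen on an aromatic ring gives a 3.0-fold lower number from compound 3 to compound 4 (0.48 log units; beyond the scatter) and is the first change that can be read at a single place. The group on this oxygen therefore bears on the number, and here the larger carbon-only group, with its added five-membered non-aromatic ring, goes with stronger inhibition rather than weaker. No measurement bears on why this step occurs.

Still open, on these data alone, is whether the closed ring itself matters, since an open-chain group such as 2-propylphenyl or a larger ring such as 5,6,7,8-tetrahydronaphthalen-1-yl could show whether carbon count alone tracks with the number at this position. It is also unclear whether a ring holding a nitrogen or oxygen atom in place of the five-membered carbon ring would keep the number of compound 4, and whether the same swap gives a similar step on cores with a different substitution on the ring bearing the carboxylic acid.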